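Oxadiazolyl azaindolone series: aryl swap on the oxadiazole

The source may hold more compounds than are shown below. What is called first, only, known or untested is meant among the compounds shown, and "the series" means these compounds.

Measured so far:
compound 1, `CS(=O)(=O)c1ccc(-c2cnc3[nH]cc(-c4nnc(-c5ccncc5)o4)c(=O)c3c2)cc1`, 5.61%
compound 2, `O=c1c(-c2nnc(-c3ccc(Cl)cc3)o2)c[nH]c2ncc(-c3ccccc3)cc12`, 12.3%

Both compounds were run in a functional assay on HCT-116 cells (Homo sapiens) for inhibition, read by MTT assay, with a stated time of 24 h, tested at 5 uM; on this read-out higher numbers stand for more inhibition of growth at the one concentration tested and lower numbers for less inhibition of growth. Compound 1 gives 5.61% and compound 2 gives 12.3%; the gap between the two numbers lies within the scatter, so neither can be set apart from the other, and both sit at the low end of the read-out. Within the data shown here, no single-site step between measured compounds is available, so nothing is known yet about how a change on the oxadiazole ring moves the number.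

Compound 3, `Cc1cccc(-c2nnc(-c3c[nH]c4ncc(-c5ccc(S(C)(=O)=O)cc5)cc4c3=O)o2)c1`, is built on the core of compound 1. It differs in one place: 3-methylphenyl in place of pyridin-4-yl on an aromatic carbon. Compound 2, which carries a carbon-only ring on its oxadiazole, gives 12.3%, no different within the scatter from compound 1; on that basis no step beyond the scatter is expected for compound 3 in this assay, in either direction. The expected step is a number 4.4 percentage points higher from compound 1 to compound 3 (within the scatter). Compound 3 is estimated at 10%, with a range from 0% to 25%.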

Compound 3, percent growth inhibition at one concentration: 20.4%
The estimate for compound 3 lay 10.4 percentage points below the measured number; the range from low to high includes it.
By their numbers in this assay, from the lowest: compounds 1, 2 and 3 (each within the scatter of the next, the first and the last beyond it).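

On the aromatic carbon of the five-membered aromatic ring with 2 nitrogen and 1 oxygen, 3-methylphenyl in place of pyridin-4-yl gives a number 14.8 percentage points higher from compound 1 to compound 3 (beyond the scatter) in this assay. Among these compounds, this is the first single-site step and it lies beyond the scatter, so the aryl group at this place can move the number, though only modestly. The swap removes the ring nitrogen and adds a methyl in one change, and no measurement shown explains the rise or bears on which of the two matters.

Unsubstituted phenyl on the core of compound 1 would separate the loss of the ring nitrogen from the gain of the methyl, while a carboxylic acid or an amine in place of that methyl would test whether the substituent's identity matters. On these data alone, whether a larger step is available at this place remains open, as does whether the step from compound 1 to compound 3 holds with a different group on the other side of the shared core.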